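From Difluorophenyl to Nitrophenyl on a Carbonyl Carbon

A few compounds are considered here, and "the series" means these few. Any claim that something is new, unique, unknown or untested is made for them only; others in the source may bear on it.

Measured compounds in a functional assay on PC-3 cells (Homo sapiens) for cytotoxicity, read by MTT assay, with a stated time of 48 h; on this read-out higher numbers stand for weaker inhibition and lower numbers for stronger inhibition:
compound 1 `COc1cc(C(=O)C2Sc3nnc(-c4cc(OC)c(OC)c(OC)c4)n3NC2c2ccco2)cc(OC)c1OC` gives 52200 nM
compound 2 `COc1cc(-c2nnc3n2NC(c2ccco2)C(C(=O)c2ccccc2F)S3)cc(OC)c1OC` gives only a limit of the assay, > 100000 nM
compound 3 `COc1cc(-c2nnc3n2NC(c2ccco2)C(C(=O)c2ccc(F)c(F)c2)S3)cc(OC)c1OC` gives 36000 nM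

Among the numbers shown, compound 3 holds the lowest one; its nearest neighbour is compound 1, and the step of a 1.5-fold lower number from compound 1 to compound 3 (0.16 log units; within the scatter) is within the scatter. Compound 2 stands apart as a limit (the limit of > 100000 nM in this assay, at which 1 of the 3 values shown sits).

The compound not yet measured is compound 4 `COc1cc(-c2nnc3n2NC(c2ccco2)C(C(=O)c2ccc([N+](=O)[O-])cc2)S3)cc(OC)c1OC`. It differs from compound 3 in one place: 4-nitrophenyl in place of 3,4-difluorophenyl on a carbonyl carbon.

All three measured steps change the group on this same carbonyl carbon. The steps of an at least 1.9-fold higher number from compound 1 to compound 2 (0.28 log units; that floor lies within the scatter) and a 1.5-fold lower number from compound 1 to compound 3 (0.16 log units; within the scatter) were small, and only an at least 2.7-fold lower number from compound 2 to compound 3 (0.44 log units; beyond the scatter) reached beyond the scatter. The change to compound 4 is therefore expected to move this assay little, with no clear direction. Compound 4 is expected to give 45000 nM, with a range from 15000 nM to 120000 nM. This amounts to an expected step of a 1.3-fold higher number from compound 3 to compound 4 (0.10 log units; within the scatter).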

Compound 4, half-maximal inhibitory concentration: 27900 nM
For compound 4 the middle estimate is 1.6-fold (0.21 log units) above the measured one; the range from low to high includes it.
By their numbers in this assay, from the lowest: compounds 4, 3 and 1 (each within the scatter of the next). At a limit, above all of these: compound 2.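

In this assay, 4-nitrophenyl on this carbonyl carbon stands level with 3,4-difluorophenyl (a 1.3-fold lower number from compound 3 to compound 4 (0.11 log units; within the scatter)) and with 3,4,5-trimethoxyphenyl (a 1.9-fold lower number from compound 1 to compound 4 (0.27 log units; within the scatter)). Three differently substituted phenyl rings now sit within the scatter of one another, and compound 2, with its 2-fluorophenyl, is the one that goes against this, as a second clear step now shows (an at least 3.5-fold lower number from compound 2 to compound 4 (0.55 log units; beyond the scatter)). That step has only a floor, since compound 2 gives a limit and not a number: the limit of > 100000 nM in this assay, at which 1 of the 4 values shown sits.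

All the compounds shown keep a phenyl ring on this carbon, so an amine or a short alkyl chain there remains an open case. A 4-fluorophenyl group would show whether a single fluorine on the ring goes with the limit seen for compound 2.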